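From Trifluoromethyl to Fluoro in a Level Series

The source may report more compounds than this note shows. Statements on the series, on what has been measured and on what is new or still open speak of the compounds shown alone.

Of the compounds shown here, three with a shared core have been measured so far. In a functional assay on HL-60 cells (Homo sapiens) for inhibition, read by MTT assay, with a stated time of 72 h (a lower number here means a stronger inhibitor, a higher number a weaker inhibitor), compound 1 `Cc1nc(-c2ccccc2)c(C(=O)N2CCN(c3cccc(Cl)c3Cl)CC2)o1` gives 133 nM while compound 2 `Cc1nc(-c2ccccc2)c(C(=O)N2CCN(c3c(C)cccc3C)CC2)o1` gives 146 nM and compound 3 `Cc1nc(-c2ccccc2)c(C(=O)N2CCN(c3cccc(C(F)(F)F)c3)CC2)o1` gives 153 nM in the same test. Compound 3 stands level with the other two: the steps of a 1.2-fold higher number from compound 1 to compound 3 (0.06 log units; within the scatter) and a 1.0-fold higher number from compound 2 to compound 3 (0.02 log units; within the scatter) both lie within the scatter.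

For the measured compounds named here, compound 4 `Cc1nc(-c2ccccc2)c(C(=O)N2CCN(c3cccc(F)c3)CC2)o1` has fluoro in place of trifluoromethyl on an aromatic carbon and no measured step makes this exact swap. The closest evidence comes from exchanging the whole substituted phenyl on the amine nitrogen, where the step of a 1.1-fold higher number from compound 1 to compound 2 (0.04 log units; within the scatter) also stays within the scatter. Three compounds are thin evidence, but they give no reason to expect a step beyond the scatter in this assay here. The estimated change is a 1.0-fold higher number from compound 3 to compound 4 (0.02 log units; within the scatter) with no firm direction expected. Compound 4 is expected at 160 nM with an estimated range from 70 nM to 370 nM across repeated measurements.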

Compound 4, half-maximal inhibitory concentration: 45 nM
Beside the measured number, compound 4's estimate is 3.6-fold (0.55 log units) above it; measured number outside the range, below it.
By their numbers in this assay, from the lowest: compound 4; then compounds 1, 2 and 3 (each within the scatter of the next).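

The phenyl group on the ring amine nitrogen turns out to matter more than the first three compounds suggested: in this assay, fluoro in place of trifluoromethyl on this aromatic carbon gives a 3.4-fold lower number from compound 3 to compound 4 (0.53 log units; beyond the scatter) and so opens the first gap beyond the scatter in the series. The exchanges of the whole substituted phenyl agree, with a 3.2-fold lower number from compound 2 to compound 4 (0.51 log units; beyond the scatter) and a 3.0-fold lower number from compound 1 to compound 4 (0.47 log units; beyond the scatter) both printed as beyond the scatter, so 3-fluorophenyl stands apart from three groups that remain level with one another. No supporting measurement is available to explain this gap.

The compounds shown leave open how a nitrile or a methoxy group on the same aromatic carbon would compare with fluoro. They also leave open whether fluoro would give a similar number at another place on the ring.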